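The compounds below may be only part of what the source reports. "The series", "measured", "known", "first", "only" and "open" are said of these compounds alone.

In an assay on CHO cells for displacement of a labelled ligand from adenosine receptor A2b (Homo sapiens), read by scintillation counting, with a stated time of 75 min, in the presence of a further agent that is not named here (on this read-out higher numbers stand for weaker inhibition and lower numbers for stronger inhibition), compound 1 `CCCn1c(=O)[nH]c2nc(-c3ccc(S(=O)(=O)N4CCN(c5ccc(Cl)cc5F)CC4)cc3)[nH]c2c1=O` gives 1.91 nM. Among the three compounds measured, compound 1 stands second highest: compound 2 `CCCn1c(=O)[nH]c2nc(-c3ccc(S(=O)(=O)N4CCN(c5ccccc5F)CC4)cc3)[nH]c2c1=O` gives 3.22 nM, a step of a 1.7-fold higher number from compound 1 to compound 2 (0.23 log units; within the scatter), and compound 3 `CCCn1c(=O)[nH]c2nc(-c3ccc(S(=O)(=O)N4CCN(c5ccc(C)cc5)CC4)cc3)[nH]c2c1=O` gives 0.706 nM, a step of a 2.7-fold lower number from compound 1 to compound 3 (0.43 log units; beyond the scatter). Compound 4 `CCCn1c(=O)[nH]c2nc(-c3ccc(S(=O)(=O)N4CCN(Cc5ccc(Br)c(F)c5)CC4)cc3)[nH]c2c1=O` differs from compound 1 in one place: 4-bromo-3-fluorobenzyl in place of 4-chloro-2-fluorophenyl on an amine nitrogen in a ring. The steps that touch the same ring nitrogen, a 2.7-fold lower number from compound 1 to compound 3 (0.43 log units; beyond the scatter) and a 4.6-fold lower number from compound 2 to compound 3 (0.66 log units; beyond the scatter), were modest, and a 1.7-fold higher number from compound 1 to compound 2 (0.23 log units; within the scatter) lay within the scatter, so changes there have moved the numbers only a little. Among the compounds with values here, none of the measured steps, however, puts a benzyl group on that nitrogen, so the expectation is uncertain. Relative to compound 1, the estimated step to compound 4 is a 1.8-fold higher number from compound 1 to compound 4 (0.26 log units; within the scatter). Compound 4 is therefore expected at 3.5 nM, within 1 nM to 12 nM.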

Compound 4, inhibition constant: 0.473 nM
Compound 4: middle estimate off by 7.4-fold (0.87 log units), on the high side; measured number outside the range, below it.
By their numbers in this assay, from the lowest: compounds 4 and 3 (each within the scatter of the next); then compounds 1 and 2 (each within the scatter of the next).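

Putting a benzyl group on the ring nitrogen, in place of a phenyl group attached directly, is tolerated in this assay: the numbers show a 4.0-fold lower number from compound 1 to compound 4 (0.61 log units; beyond the scatter) and a 6.8-fold lower number from compound 2 to compound 4 (0.83 log units; beyond the scatter) and both steps are modest. Against the 4-methylphenyl group, the change gives a 1.5-fold lower number from compound 3 to compound 4 (0.17 log units; within the scatter) so both kinds of group can reach the lowest numbers seen here. No evidence is available to explain this result.

Compound 4 changes the link and the halogens together, so their contributions cannot be separated. From the compounds shown here alone, whether unsubstituted benzyl or a longer chain such as 2-phenylethyl would give similar numbers remains open.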